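Opening a Chain Series: From Propargyl Toward Pentyl

The compounds below may be only part of what the source reports. "The series", "measured", "known", "first", "only" and "open" are said of these compounds alone.

The shared core carries an amide whose nitrogen bears a varying group. Compound 1 `COc1ccc2nc(C)cc(OCC(=O)Nc3ccc(C)cc3)c2c1` has a 4-methylphenyl there, and in an ADME assay on HepG2 cells (Homo sapiens) for cytotoxicity, read by trypan blue exclusion, with a stated time of 48 h, in the presence of a further agent that is not named here (a lower number here means that less compound is tolerated, a higher number that more compound is tolerated), compound 1 gives 41500 nM. Compound 2 `COc1ccc2nc(C)cc(OCC(=O)NCCCc3ccccc3)c2c1` has a 3-phenylpropyl there, and in this assay compound 2 gives 50700 nM, a step of a 1.2-fold higher number from compound 1 to compound 2 (0.09 log units; within the scatter). Compound 3 `C#CCNC(=O)COc1cc(C)nc2ccc(OC)cc12` carries a propargyl, and in this assay compound 3 gives > 176000 nM, which is a limit of the assay rather than a number. Compound 3 thus sits at the top of the numbers shown, a position marked by the limit of > 176000 nM in this assay, at which 1 of the 3 values shown sits. The steps to it were an at least 4.2-fold higher number from compound 1 to compound 3 (0.62 log units; beyond the scatter) and an at least 3.4-fold higher number from compound 2 to compound 3 (0.54 log units; beyond the scatter), both beyond the scatter.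

Compound 4 `CCCCCNC(=O)COc1cc(C)nc2ccc(OC)cc12` is the next compound. The change from compound 3 is butyl in place of ethynyl on a saturated chain carbon bound to an amide-type nitrogen. The bearing steps are those into compound 3: replacing the aromatic or phenethyl-bearing groups by propargyl raised the number in this assay. Moving to a plain butyl has no direct precedent here; the chain of compound 2 sat lower, the propargyl of compound 3 at the limit. Compound 4 is therefore expected to stay near the limit, with a step of an at least 1.1-fold lower number from compound 3 to compound 4 (0.06 log units; that floor lies within the scatter). The estimate for compound 4 in this assay is 150000 nM, expected between 50000 nM and 250000 nM.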

Compound 4, half-maximal cytotoxic concentration: 106000 nM
Estimate against measurement, compound 4: 1.4-fold (0.15 log units) above, and the stated range covers the measured number.
By their numbers in this assay, from the lowest: compounds 1 and 2 (each within the scatter of the next); then compound 4. At a limit, above all of these: compound 3.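

In this assay, the pentyl group shows that a chain with no ring and no triple bond on the amide-type nitrogen also gives a higher number than the ring-bearing groups, with a 2.6-fold higher number from compound 1 to compound 4 (0.41 log units; beyond the scatter) and a 2.1-fold higher number from compound 2 to compound 4 (0.32 log units; beyond the scatter). The second of these steps is the closer comparison, since most of the chain stays in place and ethyl takes the place of phenyl, so a triple bond is not required for a rise over compound 2. The step from propargyl to pentyl reads an at least 1.6-fold lower number from compound 3 to compound 4 (0.22 log units; that floor lies within the scatter); that is a floor and not a size, as the value of compound 3 is a limit of the assay: the limit of > 176000 nM in this assay, at which 1 of the 4 values shown sits.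

Going by these compounds, whether the number follows chain length stays open, and a propyl group or a longer chain such as octyl on the same nitrogen would test that. On these data alone, how an amine or a carboxylic acid at the end of the chain would read in this assay also remains unknown from these compounds.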